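The compounds below may be only part of what the source reports. "The series", "measured", "known", "first", "only" and "open" are said of these compounds alone.

Compound 1 `Brc1cccc2c1nnn2CC1CCC1` gives 12 mL/min/g in an ADME assay on microsomes from liver (Rattus norvegicus, strain Wistar) for metabolic stability, tested at 2.5 uM; a higher number here means faster removal of the compound, a lower number slower removal. Compound 2 `CC(C)Cn1nnc2c(Br)cccc21` gives 4 mL/min/g in this assay, the lower of the two numbers recorded, the change being a 3.0-fold lower number from compound 1 to compound 2 (0.48 log units; beyond the scatter). Compound 3 `CCCn1nnc2c(Br)cccc21` differs from compound 2 by hydrogen in place of methyl on a saturated chain carbon bound to two saturated chain carbons. Within the data shown here, the one measured step, from compound 1 to compound 2, is the only guide and trims the same chain; its size was modest. Compound 3 is therefore expected to move in the same direction, by a 1.3-fold lower number from compound 2 to compound 3 (0.12 log units; within the scatter), though a result within the scatter would not surprise. Compound 3 is estimated at 3 mL/min/g, with a range from 1.5 mL/min/g to 7 mL/min/g.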

Compound 3, intrinsic clearance in a liver preparation (reported as CLH), per the amount of preparation that the assay uses: 0.8 mL/min/g
Beside the measured number, compound 3's estimate is 3.8-fold (0.57 log units) above it; measured number below the stated range.
By their numbers in this assay, from the lowest: compound 3; then compound 2; then compound 1.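

Going from isobutyl to propyl at this position gives a 5.0-fold lower number from compound 2 to compound 3 (0.70 log units; beyond the scatter) in this assay, so the fall seen on leaving cyclobutyl continues once the branching methyl is gone. Across the whole run there is a 15-fold lower number from compound 1 to compound 3 (1.18 log units; beyond the scatter) and the three compounds fall in a single order, with none against it. Nothing available accounts for the size of these steps. Still open, going by these compounds, is whether a longer chain such as butyl, or an amine or a hydroxyl on the propyl chain, would keep the number this low.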